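A few compounds are considered here, and "the series" means these few. Any claim that something is new, unique, unknown or untested is made for them only; others in the source may bear on it.

Working notes on the series. Compound 1 `CCCCCCCCCCCSC[C@H](NC(C)=O)C(=O)CCl` and compound 2 `CCCCCCCCCCCCCCCCCCCCSC[C@H](NC(C)=O)C(=O)CCl` share the same core and differ only in the length of the saturated chain on the sulfur. In a functional assay on NALM-6 cells (Homo sapiens) (a higher number here means a weaker inhibitor, a lower number a stronger inhibitor), compound 1 gives 1700 nM. For compound 2 the read-out in this assay is a limit of the assay, > 100000 nM, so only a bound and no number is known for it. The step of an at least 58-fold higher number from compound 1 to compound 2 (1.76 log units; beyond the scatter) is accordingly itself a lower bound on the loss of potency, and compound 2 sits at the limit of > 100000 nM in this assay, at which 1 of the 2 values shown sits.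

Compound 3 `CCCCCCCCCCCCCCCCCCCCCCSC[C@H](NC(C)=O)C(=O)CCl` differs from compound 2 by ethyl in place of hydrogen on a saturated chain carbon, ten or more bonds along the chain from a sulfur. Within the data shown here, the one measured step that bears on this kind of change is the chain extension an at least 58-fold higher number from compound 1 to compound 2 (1.76 log units; beyond the scatter), which went toward a weaker inhibitor and was large. A further extension of the same chain is therefore expected to leave the inhibitory concentration at or past the limit rather than to recover potency, and the expected step that the limit leaves unreadable from compound 2 to compound 3 is flat or upward in this assay. Compound 3 is expected to give 200000 nM in this assay, with a range from 60000 nM to 1000000 nM.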

Compound 3, half-maximal inhibitory concentration: > 100000 nM
Compound 3 gave a limit, no number; the forecaster's own chance of this, stated with the estimate: 85%; the middle value does not contradict the limit.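

Extending the chain further gives an at least 58-fold higher number from compound 1 to compound 3 (1.76 log units; beyond the scatter), which is again only a lower bound on the loss of potency. The step from compound 2 to compound 3 cannot be read, so the two longest chains cannot be ordered against each other. What the ethyl change does show is that this added length on compound 2 does not bring the read-out back into the measurable range of this assay: the limit of > 100000 nM in this assay, at which 2 of the 3 values shown sit.

The compounds shown leave open how the inhibitory concentration runs across chains of intermediate length between those of compound 1 and compound 2, and whether a chain shorter than that of compound 1 gives a lower number. They also leave open whether a chain of similar length carrying a carboxylic acid or an amine would keep a measurable value in this assay.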